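Swapping an aryl group for an aryl sulfonyl on the ring nitrogen

The source may report more compounds than this note shows. Statements on the series, on what has been measured and on what is new or still open speak of the compounds shown alone.

Measured so far:
compound 1 `Cc1ccc(N2CCN(c3ccc(C(=O)/C=C/c4ccccc4)cc3)CC2)cc1` — 2.85%
compound 2 `O=C(/C=C/c1ccc(Cl)cc1)c1ccc(N2CCN(S(=O)(=O)c3ccc(Cl)cc3)CC2)cc1` — 56.6%

Of the compounds shown here, two have been measured in a functional assay on the whole organism (strain Kunming) for inhibition, with Mus musculus as the target, with a stated time of 1 h, at a dose of 40 mg/kg by the oral route; a lower number here means less inhibition, a higher number more inhibition at the dose given (going by the name of the read-out). Compound 1 gives 2.85%, the lower of the two numbers. Compound 2 gives 56.6%, a value that lies beyond the scatter above that of compound 1; since compound 2 differs from compound 1 in more than one place, nothing is known about which change carries that gap.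

Compound 3 `O=C(/C=C/c1ccccc1)c1ccc(N2CCN(S(=O)(=O)c3ccc(Br)cc3)CC2)cc1` has not yet been measured. It differs from compound 1 in one place: (4-bromophenyl)sulfonyl in place of 4-methylphenyl on an amine nitrogen in a ring. Within the data shown here, the entering group is of the same kind as the one compound 2 carries on its ring nitrogen, while the rest of compound 3 matches compound 1. Among the measured compounds shown here, on these two data points alone, compound 3 is expected to move upward from compound 1 by a step of a number 37.2 percentage points higher from compound 1 to compound 3 (beyond the scatter), a rise beyond the scatter but with wide uncertainty, because the only higher value comes from compound 2 at 56.6%, a compound altered in two places. Compound 3 is estimated at 40%, within a range from 15% to 62%.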

Compound 3, a percentage reported as inhibition, in the whole organism at one dose (the size of the read-out at that dose, not a potency): 47.4%
Estimate against measurement, compound 3: 7.4 percentage points below; measured number inside the range.
By their numbers in this assay, from the lowest: compound 1; then compounds 3 and 2 (each within the scatter of the next).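

In this assay, among these compounds, the single change on the ring nitrogen carries a large rise by itself: (4-bromophenyl)sulfonyl in place of 4-methylphenyl gives a number 44.6 percentage points higher from compound 1 to compound 3 (beyond the scatter) with the rest of the core of compound 1 untouched. The earlier gap lay between compounds that differ in more than one place and could not be assigned to any one change, whereas this step ties a rise beyond the scatter to one site, an amine nitrogen in a ring. No supporting data bear on why the swap has this size.

This one step brings in the sulfonyl link and the bromine together and removes the methyl, so the compounds shown cannot say which of these carries the rise; a plain phenylsulfonyl or a (4-methylphenyl)sulfonyl group on the same nitrogen would separate them. From the compounds shown here alone, it also remains open whether the sulfonyl link itself matters, which a benzoyl group at this nitrogen would test, or whether the aryl ring on it is needed, which a methanesulfonyl group would test.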